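A few compounds are considered here, and "the series" means these few. Any claim that something is new, unique, unknown or untested is made for them only; others in the source may bear on it.

Compound 1 `c1cncc(-c2ccccc2OCC2=NCCN2)c1` in a functional assay for activation of Alpha-1B adrenergic receptor (Homo sapiens), read by calcium flux; a higher number here means that more compound is needed for the effect, a lower number that less compound is needed: 79.4 nM.
Compound 2 `c1ccc(-c2ccncc2)c(OCC2=NCCN2)c1` in this assay: compound 2 reaches only a limit, < 100000 nM.
Compound 3 `c1csc(-c2ccccc2OCC2=NCCN2)c1` in this assay: 3.98 nM.

Compound 3 holds the lowest of the two numbers given, reached by a 20-fold lower number from compound 1 to compound 3 (1.30 log units; beyond the scatter). Compound 4 `c1ccc(-c2ccoc2)c(OCC2=NCCN2)c1` differs from it by furan-3-yl in place of thiophen-2-yl on an aromatic carbon. Among the measured compounds shown here, no measured step exchanges one five-membered ring for another; the only step touching thiophen-2-yl, a 20-fold lower number from compound 1 to compound 3 (1.30 log units; beyond the scatter), was large, while a step that the limit leaves unreadable from compound 1 to compound 2 and a step that the limit leaves unreadable from compound 2 to compound 3 stay unreadable because of the limit of < 100000 nM in this assay, at which 1 of the 3 values shown sits. Compound 4 is therefore expected to keep a low number, with a 3.0-fold higher number from compound 3 to compound 4 (0.48 log units; beyond the scatter) as a small step that may lie within the scatter. For compound 4 the estimate in this assay is 12 nM, between 3 nM and 60 nM.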

Compound 4, half-maximal effective concentration: 5.01 nM
For compound 4 the middle estimate is 2.4-fold (0.38 log units) above the measured one; measured number inside the range.
By their numbers in this assay, from the lowest: compounds 3 and 4 (each within the scatter of the next); then compound 1.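

In this assay, among the compounds shown here, the first exchange of one five-membered aromatic ring for another, furan-3-yl for thiophen-2-yl, gives a 1.3-fold higher number from compound 3 to compound 4 (0.10 log units; within the scatter), so at this position the change of sulfur to oxygen together with the shift in ring attachment leaves the number unchanged within the scatter. The furan-3-yl group also repeats the large gain over pyridin-3-yl, with a 16-fold lower number from compound 1 to compound 4 (1.20 log units; beyond the scatter). The steps to and from compound 2 cannot be read, as its value is a limit: the limit of < 100000 nM in this assay, at which 1 of the 4 values shown sits.

The compounds shown leave open how furan-2-yl or thiophen-3-yl would behave, which would separate the hetero atom from the point of attachment. They also leave open what a plain phenyl ring or an amine would do at this position.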